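A few compounds are considered here, and "the series" means these few. Any claim that something is new, unique, unknown or untested is made for them only; others in the source may bear on it.

Of the compounds shown here, three have been tested in an assay on isolated protein for inhibition of Rho-associated protein kinase 1 (Homo sapiens), read by scintillation counting, radiometric assay and 33P incorporation, with a stated time of 40 min, in the presence of a further agent that is not named here; a higher number here means a weaker inhibitor, a lower number a stronger inhibitor. Compound 1, `COc1cccc(OCC(=O)Nc2cccc(NC(=O)c3ccc(N(C)C)cc3)c2)c1`, returns only a limit: in this assay compound 1 gives > 10000 nM. Compound 2, `Cc1coc2cc(OCC(=O)Nc3cccc(NC(=O)c4ccc(N(C)C)cc4)c3)ccc2c1=O`, likewise returns only a limit, and in this assay compound 2 gives > 10000 nM. Among the compounds with values here, compound 3, `CCCc1ccc(C(=O)Nc2cccc(NC(=O)COc3ccc4c(=O)ccoc4c3)c2)cc1`, is the one member for which a number is recorded: in this assay compound 3 gives 143 nM. Within the data shown here, compound 3 therefore stands alone as the single measured value, while the limit of > 10000 nM in this assay, at which 2 of the 3 values shown sit, marks where the other two sit. Among the measured compounds shown here, no step between two measured compounds that differ in a single place is available, so nothing within this set tells how one change shifts the read-out.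

The next compound, compound 4, `NCc1ccc(C(=O)Nc2cccc(NC(=O)COc3ccc4c(=O)ccoc4c3)c2)cc1`, differs from compound 3 in one place: amino in place of ethyl on a saturated chain carbon bound to an aromatic carbon. For the measured compounds named here, with no measured step to lean on, the expectation rests on compound 3 alone. A modest move toward stronger inhibition is expected, with the step from compound 3 to compound 4 estimated at a 2.0-fold lower number from compound 3 to compound 4 (0.31 log units; beyond the scatter), though a result within the usual scatter would not surprise. Compound 4 is expected to give about 70 nM in this assay, in a range from 15 nM to 350 nM.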

Compound 4, half-maximal inhibitory concentration: 532 nM
The estimate for compound 4 lay 7.6-fold (0.88 log units) below the measured number; measured number above the stated range.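

In this assay, within the data shown here, the replacement of ethyl by amino on a saturated chain carbon bound to an aromatic carbon gives a 3.7-fold higher number from compound 3 to compound 4 (0.57 log units; beyond the scatter) and so provides the first evidence that this place responds to a single change, here toward weaker inhibition. The step also shows that the 4-propylphenyl group can give way to 4-(aminomethyl)phenyl without the loss of a measurable result, since compound 4 gives 532 nM and not a limit. Nothing measured among these compounds accounts for the size or direction of this step.

Because propyl and aminomethyl differ both in the atoms of the chain and in its end group, this single step does not separate the effect of removing the ethyl from that of adding the amino group, and a plain methyl, an ethyl carrying a terminal amine, or a hydroxymethyl at the same place would each bear on that question. As far as these compounds go, it also remains open whether a longer chain than propyl, or a carboxylic acid at the end of the chain, would move the number in either direction.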